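Swapping Fluoro for Chloro on the Urea Aryl Ring

This account rests on a few compounds, and the source may have more. Where it says the series, first, only, none or still open, it means among the compounds named here.

Compound 1 `CN(C)CCCNc1nc(-c2ccc(NC(=O)Nc3ccccc3F)cc2)nc2ccsc12` and compound 2 `CN(C)CCCNc1nc(-c2ccc(NC(=O)Nc3ccccc3Cl)cc2)nc2ccsc12` share one core, while compound 3 `CCN(CC)CCCNc1nc(-c2ccc(NC(=O)Nc3ccc(F)cc3)cc2)nc2c(Cl)c(Cl)sc12` and compound 4 `CCN(CC)CCCNc1nc(-c2ccc(NC(=O)Nc3ccc(Cl)cc3)cc2)nc2c(Cl)c(Cl)sc12` share another; the difference between the two cores is not broken down here. In a functional assay on NCI-H460 cells (Homo sapiens) for cytotoxicity, read by MTT assay, with a stated time of 72 h (a higher number here means a weaker inhibitor, a lower number a stronger inhibitor), compound 1 gives 530 nM and compound 2 gives 430 nM. The change from the first to the second is chloro in place of fluoro on an aromatic carbon and it made a 1.2-fold lower number from compound 1 to compound 2 (0.09 log units; within the scatter). In this assay compound 3 gives 450 nM. Compound 4 carries the same kind of change, (chloro in place of fluoro on an aromatic carbon), though here the place is para to a large group rather than ortho to a large group. Because the earlier step of a 1.2-fold lower number from compound 1 to compound 2 (0.09 log units; within the scatter) stayed within the scatter, compound 4 is expected to sit close to compound 3 as well. Compound 4 is therefore estimated at 400 nM, expected to fall between 200 nM and 800 nM, an expected step of a 1.1-fold lower number from compound 3 to compound 4 (0.05 log units; within the scatter).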

Compound 4, half-maximal inhibitory concentration: 270 nM
Compound 4: the middle estimate sits 1.5-fold (0.17 log units) above what was measured; measured number inside the range.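

In this assay, chloro in place of fluoro gives a 1.7-fold lower number from compound 3 to compound 4 (0.22 log units; within the scatter). So far as this assay can tell, the change carries over from one core to the other without a detectable difference: the same change on two cores in this assay, a 1.2-fold lower number (0.09 log units; within the scatter) from compound 1 to compound 2 and a 1.7-fold lower number (0.22 log units; within the scatter) from compound 3 to compound 4, 1.4-fold (0.13 log units) apart, within the scatter of two such steps. This does not show that the change itself has a real effect on either core, and the two pairs differ in both core and ring position, so the influence of each cannot be separated.

The compounds shown leave open how a bromo or methoxy group in the same place would compare. They also leave open whether the result would hold with a longer chain ending in the amine.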